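A few compounds are considered here, and "the series" means these few. Any claim that something is new, unique, unknown or untested is made for them only; others in the source may bear on it.

Measured in a functional assay on MC-38 cells (Mus musculus) for antiproliferative activity; a higher number here means a weaker inhibitor, a lower number a stronger inhibitor:
- compound 1 `N#Cc1c[nH]c2c(NS(=O)(=O)c3ccc(C(N)=O)cc3)cccc12`: 0.68 ug/mL
- compound 2 `N#Cc1c[nH]c2c(NS(=O)(=O)c3ccc(N)cc3)cccc12`: 0.28 ug/mL
- compound 3 `CS(=O)(=O)Nc1ccc(S(=O)(=O)Nc2cccc3c(C#N)c[nH]c23)cc1`: 1.2 ug/mL

Compound 3 sits within the usual scatter of compound 1, as a 1.8-fold higher number from compound 1 to compound 3 (0.25 log units; within the scatter) shows, while a 4.3-fold higher number from compound 2 to compound 3 (0.63 log units; beyond the scatter) separates it from compound 2.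

Compound 4 `CS(=O)(=O)Nc1ccc(S(=O)(=O)Nc2cccc3c(Cl)c[nH]c23)cc1` has chloro in place of cyano on an aromatic carbon. Within the data shown here, no measured step touches this group, since all three alter a different part of the molecule. They therefore give only a rough sense of size, and the largest is the modest 4.3-fold higher number from compound 2 to compound 3 (0.63 log units; beyond the scatter). The data give no direction for this swap. The estimated step is a 1.2-fold lower number from compound 3 to compound 4 (0.08 log units; within the scatter), so no shift beyond the scatter is expected. Compound 4 is expected at 1 ug/mL, with an estimated range from 0.3 ug/mL to 3.5 ug/mL.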

Compound 4, half-maximal inhibitory concentration: 0.26 ug/mL
Beside the measured number, compound 4's estimate is 3.8-fold (0.59 log units) above it; measured number outside the range, below it.
By their numbers in this assay, from the lowest: compounds 4 and 2 (each within the scatter of the next); then compounds 1 and 3 (each within the scatter of the next).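

In this assay, the step for chloro in place of cyano is a 4.6-fold lower number from compound 3 to compound 4 (0.66 log units; beyond the scatter) and lies beyond the scatter. Among these compounds, this carbon of the five-membered aromatic ring, two ring bonds from the ring nitrogen, therefore affects the read-out, which the earlier steps at another part of the molecule could not show. Nothing available explains this drop.

From the compounds shown here alone, whether the result is particular to chloro remains open, and bromo or methyl on the same carbon would test this. Also open, going by these compounds, is whether the swap gives a similar step with the amino group of compound 2 or the carbamoyl group of compound 1.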